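Trading a tert-butyl for methyl on a weak inhibitor

The compounds below may be only part of what the source reports. "The series", "measured", "known", "first", "only" and "open" are said of these compounds alone.

Of the compounds shown here, three sharing one core have been measured in an assay on isolated protein for inhibition of Voltage-dependent L-type calcium channel subunit alpha-1C (Cavia porcellus); a lower number here means a stronger inhibitor, a higher number a weaker inhibitor. Compound 1 `CC1=C(C(=O)OCC(C)C)C(c2[nH]cnc2Cl)C(C(=O)OCC(C)C)=C(C)N1` gives 95.5 nM, and compound 3 `CC1=C(C(=O)OC2CCCC2)C(c2[nH]cnc2Cl)C(C(=O)OC2CCCC2)=C(C)N1` gives 97.7 nM; these two values lie within the usual scatter of each other. Compound 2 `CC1=C(C(=O)OC(C)(C)C)C(c2[nH]cnc2Cl)C(C(=O)OC(C)(C)C)=C(C)N1` stands apart with 4070 nM, the highest of the three numbers and thus the weakest inhibitor shown, its gap to compound 3 and to compound 1 lying well beyond the scatter.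

Compound 4 `COC(=O)C1=C(C)NC(C)=C(C(=O)OC(C)(C)C)C1c1[nH]cnc1Cl` has not yet been measured in this assay. It differs from compound 2 by methyl in place of tert-butyl on an oxygen next to a carbonyl group, so that only the other side of the core still carries the group that compound 2 has at both places. Compounds 1 and 3 show that this core can give a low number when the groups on the oxygens are not tert-butyl, while compound 2 shows that tert-butyl at both places goes with a high number. A move away from tert-butyl at one place is therefore expected to pull the number down, by a step estimated at a 14-fold lower number from compound 2 to compound 4 (1.13 log units; beyond the scatter). For compound 4 the expected value is 300 nM, within a range of 60 nM to 1500 nM.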

Compound 4, half-maximal inhibitory concentration: 1860 nM
The estimate for compound 4 lay 6.2-fold (0.79 log units) below the measured number; the whole stated range lies below it.
By their numbers in this assay, from the lowest: compounds 1 and 3 (each within the scatter of the next); then compound 4; then compound 2.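

Going by these compounds alone, this is the first step where only one place changes, since compounds 1, 2 and 3 differ from one another at both places at once. In this assay, methyl in place of tert-butyl on an oxygen next to a carbonyl group gives a 2.2-fold lower number from compound 2 to compound 4 (0.34 log units; beyond the scatter), a modest step that lies beyond the scatter, so removing tert-butyl from this one place does lower the number, though only by a small amount while the other place still carries tert-butyl. No measurement at hand explains why the step has this size.

The compounds shown leave open how the number would respond to other groups on this oxygen, such as ethyl or benzyl, and so whether methyl is a good choice here or merely one that happens to differ from tert-butyl. They also leave open whether the same change would give a step of similar size if the other place carried isobutyl or cyclopentyl, or methyl as well, instead of tert-butyl.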